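The source may report more compounds than this note shows. Statements on the series, on what has been measured and on what is new or still open speak of the compounds shown alone.

Compound 1 `Cc1ccc(NC2=CC(=O)c3c(nc4n3[C@H]3OC[C@@H](O)[C@H]3OC4)C2=O)cc1` was tested in a functional assay on MGC-803 cells (Homo sapiens) for inhibition, read by sulforhodamine B assay (a lower number here means a stronger inhibitor, a higher number a weaker inhibitor), where compound 1 gives 1550 nM. Its companion, compound 2 `CCOc1ccccc1NC1=CC(=O)c2nc3n(c2C1=O)[C@H]1OC[C@@H](O)[C@H]1OC3`, differs in the group carried on the amine nitrogen and gives 2450 nM in this assay. The two numbers lie within the usual scatter of repeated measurements of each other, so on the evidence available the two compounds cannot be separated, and compound 1 stands simply as one of two closely matched results.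

Compound 3 `O=C1C(Nc2cccc(F)c2)=CC(=O)c2c1nc1n2[C@H]2OC[C@@H](O)[C@H]2OC1` keeps the shared core and the amine nitrogen but changes the aromatic group attached to it: 3-fluorophenyl in place of 4-methylphenyl on an amine nitrogen. Within the data shown here, no measured pair in this set shows what such a swap does, so the expectation must rest on the fact that two different aromatic groups on this nitrogen, in compound 1 and compound 2, land so close together. On that basis the step from compound 1 to compound 3 is expected to be small, with no clear direction beyond the scatter, and a 1.2-fold higher number from compound 1 to compound 3 (0.06 log units; within the scatter) is the estimate. Compound 3 is therefore expected to give about 1800 nM in this assay, within a range of 700 nM to 4500 nM.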

Compound 3, half-maximal inhibitory concentration: 1470 nM
Beside the measured number, compound 3's estimate is 1.2-fold (0.09 log units) above it, within the range that was stated.
By their numbers in this assay, from the lowest: compounds 3, 1 and 2 (each within the scatter of the next).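

Among these compounds, this is the first step here between two compounds that differ in one place: in this assay, putting 3-fluorophenyl in place of 4-methylphenyl on the amine nitrogen gives a 1.1-fold lower number from compound 1 to compound 3 (0.02 log units; within the scatter). The two groups have the same count of heavy atoms and each carries one six-membered aromatic ring of carbon only, so this pair shows that this particular exchange of one aromatic group for another leaves the reading indistinguishable from that of compound 1. No measurement available here offers an explanation for why these two groups read alike.

The step changes the methyl to a fluorine and also changes the number in the group's name, so a matching 4-fluorophenyl or 3-methylphenyl group would be needed to tell those two differences apart. As far as these compounds go, it also remains open whether this nitrogen tolerates something other than a substituted phenyl ring, such as a simple alkyl chain, or a phenyl ring carrying a carboxylic acid or an amine.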